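The source may hold more compounds than are shown below. What is called first, only, known or untested is meant among the compounds shown, and "the series" means these compounds.

Measured so far in a functional assay on HL-60 cells (Homo sapiens) for inhibition, read by CCK-8 assay, with a stated time of 48 h, tested at 20 uM; on this read-out lower numbers stand for less inhibition of growth and higher numbers for more inhibition of growth at the one concentration tested:

Compound 1, `COc1ccc(Cc2nnc(NC(=O)/C(C#N)=C/c3ccccc3OS(=O)(=O)c3ccc(Cl)cc3)s2)cc1`, gives 20% in this assay.
Compound 2, `COc1ccc(Cc2nnc(NC(=O)/C(C#N)=C/c3ccccc3OS(=O)(=O)c3ccc(F)cc3)s2)cc1`, gives 25% in this assay.
Compound 3, `N#C/C(=C\c1ccccc1OS(=O)(=O)c1ccc(Cl)cc1)C(=O)Nc1nnc(Cc2cccc3ccccc23)s1`, gives 15% in this assay.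

Compound 4, `N#C/C(=C\c1ccccc1OS(=O)(=O)c1ccc(F)cc1)C(=O)Nc1nnc(Cc2cccc3ccccc23)s1`, has not yet been measured in this assay. It differs from compound 3 by fluoro in place of chloro on an aromatic carbon, and the same change, (fluoro in place of chloro on an aromatic carbon), has been made once before, giving a number 5 percentage points higher from compound 1 to compound 2 (within the scatter). The two cores on which the change sits differ by naphthalen-1-yl in place of 4-methoxyphenyl on a saturated chain carbon bound to an aromatic carbon, which gave a number 5 percentage points lower from compound 1 to compound 3 (within the scatter). The place of the change is the same in both pairs, so this counts as the same change. Given this, the step from compound 3 is expected to be small, a number 5 percentage points higher from compound 3 to compound 4 (within the scatter), resting on compound 1 and its step of a number 5 percentage points higher from compound 1 to compound 2 (within the scatter). Compound 4 is therefore estimated at 20%, between 8% and 32%.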

Compound 4, percent growth inhibition at one concentration: 12%
Estimate against measurement, compound 4: 8 percentage points above; the range from low to high includes it.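

In this assay, fluoro in place of chloro gives a number 3 percentage points lower from compound 3 to compound 4 (within the scatter), and the two readings of this change agree: the same change on two cores in this assay, a number 5 percentage points higher (within the scatter) from compound 1 to compound 2 and a number 3 percentage points lower (within the scatter) from compound 3 to compound 4, 8 percentage points apart, within the scatter of two such steps. The change from 4-methoxyphenyl to naphthalen-1-yl also reads alike on both halogen partners, even though one of its steps is a number 13 percentage points lower from compound 2 to compound 4 (beyond the scatter): the same change on two cores in this assay, a number 5 percentage points lower (within the scatter) from compound 1 to compound 3 and a number 13 percentage points lower (beyond the scatter) from compound 2 to compound 4, 8 percentage points apart, within the scatter of two such steps. This shows that the fluoro-for-chloro step carried from one core to the other without a detectable difference, but with steps this small it fixes no direction for the change and does not show that it would carry to any further core.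

Only fluoro and chloro are shown at this place on the ring, so a methyl group or an amine there remains open. Also open, from the compounds shown here alone, is how a longer chain would read in place of the 4-methoxyphenyl and naphthalen-1-yl groups.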